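This account rests on a few compounds, and the source may have more. Where it says the series, first, only, none or still open, it means among the compounds named here.

Compound 1 `Cn1c(-c2cccc(Br)c2)cnc1NC(=O)c1ccc(F)cc1` was tested in a toxicity assay on THP-1 cells (Homo sapiens) for inhibition; on this read-out higher numbers stand for lower toxicity in this test and lower numbers for higher toxicity in this test. Compound 1 gives only a limit there, > 50000 nM, not a number. Two other compounds show the same picture. Compound 2 `COc1ccc(-c2cnc(NC(=O)c3cc(-c4ccccn4)n[nH]3)n2C)cc1` gives a limit, >= 50000 nM. Compound 3 `COc1ccc(-c2cnc(NC(=O)c3cnc[nH]3)n2C)cc1` also gives a limit, > 100000 nM. Among the measured compounds shown here, every value known so far is a limit, so compound 1 stands among compounds with no measurable toxicity in this test. Compound 4 `Cn1c(-c2ccccc2)cnc1NC(=O)c1ccc(F)cc1` differs from compound 1 in one place: hydrogen in place of bromo on an aromatic carbon. For the measured compounds named here, no measured step of this kind exists among the three compounds. The change is expected to move the read-out by no more than the usual scatter, a step that the limit leaves unreadable from compound 1 to compound 4, if at all. For compound 4 the expected value is 60000 nM, with a range from 30000 nM to 120000 nM, and most likely it is again reported as a limit.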

Compound 4, half-maximal cytotoxic concentration: > 100000 nM
Compound 4: no number, only a limit (the forecaster's own chance of this, stated with the estimate: 85%); middle value at least 1.6-fold (0.22 log units) away from the limit.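

Compound 1 and compound 4 both give only limits, so no step can be read between them. The compounds shown leave open whether 3-bromophenyl or phenyl makes any difference to toxicity beyond those limits.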